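Swapping the Benzamide Ring in Two Weak Glioma Cell Inhibitors

A few compounds are considered here, and "the series" means these few. Any claim that something is new, unique, unknown or untested is made for them only; others in the source may bear on it.

Measured so far:
compound 1 `O=C(Nc1ccc(Cl)c(-c2nnc3c(Cl)cccn23)c1)c1ccccc1` gives 73500 nM
compound 2 `O=C(Nc1ccc(Cl)c(-c2nnc3c(Cl)cccn23)c1)c1c(F)cccc1Cl` gives > 100000 nM

Among the compounds with values here, in a functional assay on U-251 cells (Homo sapiens) for antiproliferative activity, read by MTT assay, with a stated time of 72 h (a higher number here means a weaker inhibitor, a lower number a stronger inhibitor), compound 1 is the only compound with a plain number; the other entry is a limit. For compound 2 the result is a limit of the assay, (the limit of > 100000 nM in this assay, at which 1 of the 2 values shown sits), so its true value is not known. The step of an at least 1.3-fold higher number from compound 1 to compound 2 (0.13 log units; that floor lies within the scatter) therefore only has a floor, and that floor lies within the scatter, so nothing beyond noise can be claimed for adding chlorine and fluorine to the phenyl in that pattern.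

Compound 3 `O=C(Nc1ccc(Cl)c(-c2nnc3c(Cl)cccn23)c1)c1ccc(F)cc1Cl` carries a related change: 2-chloro-4-fluorophenyl in place of phenyl on a carbonyl carbon. Within the data shown here, the one measured step that bears on it, an at least 1.3-fold higher number from compound 1 to compound 2 (0.13 log units; that floor lies within the scatter), shows at most a drift toward a higher number and possibly none at all. An expected step in the same direction, small or absent, is the sensible reading, with a real chance that this assay again reports only a limit.

The expected result for compound 3 is 100000 nM, with a range of 45000 nM to 250000 nM, which amounts to an expected step of a 1.4-fold higher number from compound 1 to compound 3 (0.13 log units; within the scatter).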

Compound 3, half-maximal inhibitory concentration: > 100000 nM
Compound 3 ended at the assay's limit; the forecaster's own chance of this, stated with the estimate: 50%; the middle value sits exactly at the limit.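

In this assay, shifting the fluorine from the 2-chloro-6-fluorophenyl of compound 2 to the 2-chloro-4-fluorophenyl of compound 3 still gives no readable number: the result for compound 3 is a limit, not a measured value. Set against the plain phenyl, the change gives an at least 1.3-fold higher number from compound 1 to compound 3 (0.13 log units; that floor lies within the scatter), so this second halogen pattern, like the first, supports no claim beyond noise, and a true loss of activity can be neither shown nor ruled out. The step between compound 2 and compound 3 cannot be read, and the two patterns cannot be ranked, because both compounds sit at the same ceiling: the limit of > 100000 nM in this assay, at which 2 of the 3 values shown sit.

On these data alone, how far the true values of compound 2 and compound 3 lie from that of compound 1 stays open, as does the effect of the fluorine's place on the ring. Also open, as far as these compounds go, is whether a different group on this phenyl, such as an amine or a carboxylic acid, would bring the number down from the weak level of compound 1 at 73500 nM.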